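This account rests on a few compounds, and the source may have more. Where it says the series, first, only, none or still open, it means among the compounds named here.

Compound 3 `NC(=O)c1c(NC(=O)c2ccccc2Cl)sc2c1CCN(Cc1cc(Cl)cc(Cl)c1)C2` sits second highest of the three numbers measured in a functional assay on HL-60 cells (Homo sapiens) for antiproliferative activity, with a stated time of 24 h (on this read-out higher numbers stand for weaker inhibition and lower numbers for stronger inhibition), where compound 3 gives 15800 nM; compound 1 `NC(=O)c1c(NC(=O)c2ccccc2Cl)sc2c1CCN(Cc1ccccc1)C2` gives 12000 nM and compound 2 `NC(=O)c1c(NC(=O)c2ccccc2Cl)sc2c1CCN(Cc1ccc(Cl)cc1)C2` gives 22500 nM. The change to compound 4 `NC(=O)c1c(NC(=O)c2ccccc2Cl)sc2c1CCN(C(=S)Nc1ccccc1I)C2` is a group of 10 heavy atoms (7 carbon, 1 nitrogen, 1 sulfur, 1 iodine; one six-membered aromatic ring of carbon only) in place of a group of 9 heavy atoms (7 carbon, 2 chlorine; one six-membered aromatic ring of carbon only), on an amine nitrogen in a ring. The steps measured so far, a 1.9-fold higher number from compound 1 to compound 2 (0.27 log units; within the scatter), a 1.3-fold higher number from compound 1 to compound 3 (0.12 log units; within the scatter) and a 1.4-fold lower number from compound 2 to compound 3 (0.15 log units; within the scatter), only varied chlorine on the benzyl group and all stayed within the scatter; none exchanged the whole group, so they bear on this step only loosely. With no step beyond the scatter yet seen, compound 4 is expected to move little, a 1.1-fold lower number from compound 3 to compound 4 (0.02 log units; within the scatter), though the larger change earns a wider range. The estimate for compound 4 in this assay is 15000 nM, between 4000 nM and 60000 nM.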

Compound 4, half-maximal inhibitory concentration: 4430 nM
Beside the measured number, compound 4's estimate is 3.4-fold (0.53 log units) above it; the measured number falls inside the stated range.
By their numbers in this assay, from the lowest: compound 4; then compounds 1, 3 and 2 (each within the scatter of the next).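

Among the compounds shown here, exchanging the whole benzyl group on the amine nitrogen in a ring, rather than only its chlorines, gives the first steps beyond the scatter, all modest: (a 3.6-fold lower number from compound 3 to compound 4 (0.55 log units; beyond the scatter)), (a 5.1-fold lower number from compound 2 to compound 4 (0.71 log units; beyond the scatter)) and (a 2.7-fold lower number from compound 1 to compound 4 (0.43 log units; beyond the scatter)). This position therefore responds to the group attached to it, not just to the scatter of repeat measurements. Nothing measured here accounts for these steps.

On these data alone, the entering group brings iodine, sulfur and an extra nitrogen together, so the part that matters stays open. A urea with oxygen in place of the sulfur, or bromine in place of the iodine, would help separate them.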